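Ring-Nitrogen Substituents on a Biphenyl Amide Antagonist Series

The source may hold more compounds than are shown below. What is called first, only, known or untested is meant among the compounds shown, and "the series" means these compounds.

Measured so far:
Compound 1 `O=C(Nc1ccc2c(c1)NCCC2)c1ccc(-c2ccccc2)cc1`: 7.7
Compound 2 `CN(C)CCN1CCCc2ccc(NC(=O)c3ccc(-c4ccccc4)cc3)cc21`: 7.4
Compound 3 `CC(=O)NCCN1CCCc2ccc(NC(=O)c3ccc(-c4ccccc4)cc3)cc21`: 6.9

These three compounds share one core and differ only in what sits on the nitrogen of the saturated ring, tested in a functional assay for antagonist activity at transient receptor potential cation channel subfamily V member 1 (Homo sapiens), read by FLIPR and calcium flux; a higher number here means a more potent compound, by a factor of ten per unit of this negative logarithm, a lower number a less potent compound. Compound 3 stands lowest of the three: compound 2 is nearest to it, and compound 1 is furthest, both higher by steps beyond the scatter.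

Compound 4 `CC(=O)N1CCCc2ccc(NC(=O)c3ccc(-c4ccccc4)cc3)cc21` is the next compound. Its change is acetyl in place of 2-acetamidoethyl on a nitrogen on an aromatic ring in a ring.

For the measured compounds named here, two measured steps bear on substitution of this nitrogen: a number 0.30 log units lower from compound 1 to compound 2 (within the scatter) and a number 0.80 log units lower from compound 1 to compound 3 (beyond the scatter). Both lower the number, though a substituent without a chain was not measured. The third step, a number 0.50 log units lower from compound 2 to compound 3 (beyond the scatter), shows that exchanging the group on the chain also matters. The acetyl group carries no chain and no donor, so the expected outcome for compound 4 lies between compound 3 and compound 1, with a modest upward step a number 0.30 log units higher from compound 3 to compound 4 (within the scatter) expected. The estimate for compound 4 in this assay is 7.2, expected within 6.6 to 7.8.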

Compound 4, negative logarithm of the antagonist equilibrium constant: 7.2
The estimate for compound 4 equals the measured number at the digits printed; low and high end bracket the measured number.
By their numbers in this assay, from the lowest: compounds 3, 4, 2 and 1 (each within the scatter of the next, the first and the last beyond it).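

In this assay acetyl on a nitrogen on an aromatic ring in a ring gives a number 0.50 log units lower from compound 1 to compound 4 (beyond the scatter) and so shows that a substituent without a chain also separates from the unsubstituted nitrogen, whereas the step for 2-(dimethylamino)ethyl, a number 0.30 log units lower from compound 1 to compound 2 (within the scatter), does not show this. Acetyl, with 3 heavy atoms against 6 in 2-acetamidoethyl, cannot be told apart from either chain, since the data give a number 0.30 log units higher from compound 3 to compound 4 (within the scatter) and also a number 0.20 log units lower from compound 2 to compound 4 (within the scatter) as steps within the scatter. Nothing available here accounts for these steps.

From the compounds shown here alone, it remains open whether a plain methyl group or a larger acyl group such as benzoyl on this nitrogen would stay close to compound 1. A carboxylic acid at the end of an ethyl chain also remains untested among the compounds shown here.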